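Piperazine amides: side-chain change at the carbonyl carbon

A few compounds are considered here, and "the series" means these few. Any claim that something is new, unique, unknown or untested is made for them only; others in the source may bear on it.

compound 1, `CNCC(=O)N1CCN(CCCOc2ccc(C(=O)C3CC3)cc2)CC1`, gives 79400 nM in an assay for binding affinity to histamine H2 receptor (Homo sapiens); on this read-out lower numbers stand for stronger inhibition and higher numbers for weaker inhibition
compound 2, `CC(C)N[C@H](C)C(=O)N1CCN(CCCOc2ccc(C(=O)C3CC3)cc2)CC1`, gives 50100 nM in this assay

Compound 2 holds the lower of the two numbers, yet the gap a 1.6-fold lower number from compound 1 to compound 2 (0.20 log units; within the scatter) lies within the scatter, so no order between compound 1 and compound 2 can be claimed. Compound 3, `CCC[C@@H](N)C(=O)N1CCN(CCCOc2ccc(C(=O)C3CC3)cc2)CC1`, carries the change (1-aminobutyl in place of 1-(isopropylamino)ethyl on a carbonyl carbon). Going by the values given here, the only step that bears on it is the one from compound 1 to compound 2, also at the carbonyl carbon, and it stayed within the scatter. The step of a 1.0-fold lower number from compound 2 to compound 3 (0.00 log units; within the scatter) is therefore expected to stay within the scatter as well. Compound 3 is estimated at 50000 nM, range 20000 nM to 125000 nM.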

Compound 3, inhibition constant: 60300 nM
The estimate for compound 3 lay 1.2-fold (0.08 log units) below the measured number; the range from low to high includes it.
By their numbers in this assay, from the lowest: compounds 2, 3 and 1 (each within the scatter of the next).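

At the carbonyl carbon, in this assay, replacing 1-(isopropylamino)ethyl with 1-aminobutyl gives a step within the scatter (a 1.2-fold higher number from compound 2 to compound 3 (0.08 log units; within the scatter)), and replacing (methylamino)methyl with 1-aminobutyl does the same (a 1.3-fold lower number from compound 1 to compound 3 (0.12 log units; within the scatter)). All three side chains at this place therefore read alike, and no order among them can be claimed. Nothing at hand offers an explanation for this flat reading.

On these data alone, whether a carboxylic acid or a phenyl group on this carbonyl carbon would give a step beyond the scatter remains open.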